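Amide substituent changes on a shared bicyclic core

The source may hold more compounds than are shown below. What is called first, only, known or untested is meant among the compounds shown, and "the series" means these compounds.

The series keeps the shared core of compound 1 `CC(=O)N1CC2CC(C1)N2` and varies the group on the carbonyl carbon. In an assay on SH-EP1 cells for agonist activity at Neuronal acetylcholine receptor; alpha4/beta2 (Homo sapiens), read by FLIPR and calcium flux (on this read-out higher numbers stand for an effect only at larger amounts of compound and lower numbers for an effect already at smaller amounts), compound 1 gives 9700 nM. Compound 2 `O=C(C1CCC1)N1CC2CC(C1)N2` gives 11000 nM, and compound 3 `O=C(C1CCCC1)N1CC2CC(C1)N2` gives 29000 nM. Compound 2 stands second highest of the three numbers: the step of a 1.1-fold higher number from compound 1 to compound 2 (0.05 log units; within the scatter) is within the scatter, while the gap between compound 2 and compound 3 is beyond it.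

Compound 4 `O=C([C@@H]1C[C@H]1F)N1CC2CC(C1)N2` is not yet measured. It differs from compound 2 as follows: 2-fluorocyclopropyl in place of cyclobutyl on a carbonyl carbon. Going by the values given here, the only step that bears on it, a 1.1-fold higher number from compound 1 to compound 2 (0.05 log units; within the scatter), shows that exchanging methyl for cyclobutyl on the carbonyl carbon changed nothing beyond the scatter in this assay; no measured step covers a fluorinated or three-membered ring at this position. The expectation for compound 4 is therefore no step beyond the scatter, that is a 1.1-fold lower number from compound 2 to compound 4 (0.04 log units; within the scatter). The estimate for compound 4 in this assay is 10000 nM, with a range from 4000 nM to 28000 nM.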

Compound 4, half-maximal effective concentration: 870 nM
Compound 4: the middle estimate sits 11-fold (1.06 log units) above what was measured; measured number outside the range, below it.
By their numbers in this assay, from the lowest: compound 4; then compounds 1 and 2 (each within the scatter of the next); then compound 3.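

In this assay the group on the carbonyl carbon turns out to be a position that can move the number: 2-fluorocyclopropyl brings a 13-fold lower number from compound 2 to compound 4 (1.10 log units; beyond the scatter) and an 11-fold lower number from compound 1 to compound 4 (1.05 log units; beyond the scatter), whereas methyl and cyclobutyl had stayed within the scatter of each other. The step from cyclobutyl keeps the count of heavy atoms unchanged, so that count alone does not separate these groups, while ring size and the fluorine change together in this one step. No measurement is available that offers a reason for the shift.

Which part of the change carries the step stays open: plain cyclopropyl and the other stereoisomers of 2-fluorocyclopropyl would divide the ring, the fluorine and the stereocentres. On these data alone, how an amine or a longer chain on the carbonyl carbon would read also remains open.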